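The compounds below may be only part of what the source reports. "The series", "measured", "known", "first", "only" and "open" are said of these compounds alone.

Compound 1 `CCn1c(=O)/c(=C2\Sc3ccccc3N2C)s/c1=C\c1ccncc1Nc1cc(C)ccc1C`: 2000 nM
Compound 2 `CCn1c(=O)/c(=C2\Sc3ccc(C)cc3N2C)s/c1=C\c1ccncc1Nc1ccccc1Cl`: 500 nM
Compound 3 `CCn1c(=O)/c(=C2\Sc3ccccc3N2C)s/c1=C\c1ccncc1Nc1ccccc1C`: 1200 nM

In a functional assay on PC-3 cells (Homo sapiens) for inhibition (on this read-out higher numbers stand for weaker inhibition and lower numbers for stronger inhibition), compound 3 gives 1200 nM, the second highest of the three numbers; compound 1 gives 2000 nM, within the scatter of compound 3, while compound 2 gives 500 nM, a gap beyond the scatter. Compound 4 `CCn1c(=O)/c(=C2\Sc3ccccc3N2C)s/c1=C\c1ccncc1Nc1ccccc1Cl` has not yet been measured. It differs from compound 3 in one place: chloro in place of methyl on an aromatic carbon. Within the data shown here, no measured step covers this exact exchange. Among the measured compounds shown here, the one measured step, a 1.7-fold lower number from compound 1 to compound 3 (0.22 log units; within the scatter), concerns a methyl on the shared core and stays within the scatter. Compound 2 carries the same (2-chlorophenyl)amino group as compound 4, plus that core methyl, and shows the lowest number of the three. Because a 1.7-fold lower number from compound 1 to compound 3 (0.22 log units; within the scatter) suggests the core methyl by itself matters little, the lower number of compound 2 is taken as a hint for the chloro. Compound 4 is therefore expected to reach about 600 nM, in the range 250 nM to 1500 nM, an estimated step of a 2.0-fold lower number from compound 3 to compound 4 (0.30 log units; within the scatter) in this assay.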

Compound 4, half-maximal inhibitory concentration: 780 nM
Compound 4: middle estimate off by 1.3-fold (0.11 log units), on the low side, and the stated range covers the measured number.
By their numbers in this assay, from the lowest: compounds 2, 4, 3 and 1 (each within the scatter of the next, the first and the last beyond it).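

Measured directly in this assay, chloro in place of methyl on this aromatic carbon gives a 1.5-fold lower number from compound 3 to compound 4 (0.19 log units; within the scatter), so on this core the exchange alone cannot be told apart from repeat scatter. Only the wider change, 2-chlorophenyl in place of 2,5-dimethylphenyl, passes the scatter, with a 2.6-fold lower number from compound 1 to compound 4 (0.41 log units; beyond the scatter), and that modest step joins two smaller exchanges that each stay within it. Hydrogen in place of methyl on an aromatic carbon also stays small in a second pair, with a 1.6-fold higher number from compound 2 to compound 4 (0.19 log units; within the scatter), and the two such steps point opposite ways without truly disagreeing: the same change on two cores in this assay, a 1.7-fold lower number (0.22 log units; within the scatter) from compound 1 to compound 3 and a 1.6-fold higher number (0.19 log units; within the scatter) from compound 2 to compound 4, 2.6-fold (0.41 log units) apart, within the scatter of two such steps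

The compounds shown leave open whether another group at this place, such as methoxy, a nitrile or an amine, would move the number beyond the scatter. They also cannot tell why these exchanges remain so small.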